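The source may report more compounds than this note shows. Statements on the series, on what has been measured and on what is new or still open speak of the compounds shown alone.

For the measured compounds named here, compound 1, `O=C(Nc1cccc(-n2cc(-c3ccncc3)c(-c3cc(O)cc(Cl)c3)n2)c1)Nc1ccc(Cl)c(Cl)c1`, is one of three compounds measured in a functional assay on Hs-578T cells (Homo sapiens) for inhibition, read by sulforhodamine B assay, with a stated time of 48 h, tested at 10 uM (a higher number here means a weaker effect of the compound at the concentration tested, a lower number a stronger effect), where compound 1 gives -6.42%. Compound 2, `COc1cc(Cl)cc(-c2nn(-c3cccc(NC(=O)Nc4ccc(Cl)c(Cl)c4)c3)cc2-c2ccncc2)c1`, differs from compound 1 by methyl in place of hydrogen on an oxygen on an aromatic ring, and in this assay compound 2 gives 28.5%. That single change produced a step of a number 34.9 percentage points higher from compound 1 to compound 2 (beyond the scatter). Compound 3, `O=C(Nc1cccc(-n2cc(-c3ccncc3)c(-c3cc(O)cc(Cl)c3)n2)c1)c1cc(C(F)(F)F)cc(C(F)(F)F)c1`, carries a different core; the difference between the core of compound 1 and that of compound 3 is not broken down here. In this assay compound 3 gives 65.9%, the highest of the three numbers. Compound 4, `COc1cc(Cl)cc(-c2nn(-c3cccc(NC(=O)c4cc(C(F)(F)F)cc(C(F)(F)F)c4)c3)cc2-c2ccncc2)c1`, is not yet measured and differs from compound 3 by methyl in place of hydrogen on an oxygen on an aromatic ring, the same change that separates compound 2 from compound 1. Because that change gave a number 34.9 percentage points higher from compound 1 to compound 2 (beyond the scatter), the author expects a step of similar direction for compound 4, tempered by the fact that compound 3 already stands high on the scale, estimated as a number 26.1 percentage points higher from compound 3 to compound 4 (beyond the scatter). For compound 4 in this assay the estimate is 92%, with a range from 72% to 108%.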

Compound 4, a percentage reported as activity, at one concentration (the size of the read-out at that concentration, not a potency): 81.1%
Compound 4: middle estimate off by 10.9 percentage points, on the high side; low and high end bracket the measured number.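

On the core of compound 3, going from hydroxy to methoxy gave a number 15.2 percentage points higher from compound 3 to compound 4 (beyond the scatter) in this assay, so the change weakened the effect here as it did on the core of compound 1. The direction of the change carried from one core to the other, but its size did not: the same change on two cores in this assay, a number 34.9 percentage points higher (beyond the scatter) from compound 1 to compound 2 and a number 15.2 percentage points higher (beyond the scatter) from compound 3 to compound 4, 19.7 percentage points apart, beyond the scatter of two such steps These two cores show that the size of the step cannot simply be transferred within this series, but they do not show what sets it, and two pairs give no basis for predicting the step on a third core.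

The compounds shown have only hydrogen or methyl on this oxygen, so it remains open how an ethyl group or a longer chain there would behave. On these data alone, it also remains open whether an amine in place of the hydroxy would keep the stronger effect seen with the hydroxy compounds on these two cores.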